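Aromatic Five-Membered Ring Replaces Non-Aromatic Ring on Amide

The source may hold more compounds than are shown below. What is called first, only, known or untested is meant among the compounds shown, and "the series" means these compounds.

Three compounds share one core and differ only in the group on the amide-type nitrogen. In a functional assay on CHO cells for agonist activity at Free fatty acid receptor 2 (Homo sapiens), read by cAMP accumulation (on this read-out higher numbers stand for weaker inhibition and lower numbers for stronger inhibition), compound 1 `CC(C)[C@H](C(=O)Nc1ccccn1)c1ccc(Cl)cc1` gives 1400 nM, and compound 2 `CC(C)[C@H](C(=O)Nc1ccc(F)cn1)c1ccc(Cl)cc1` gives 1300 nM; the step of a 1.1-fold lower number from compound 1 to compound 2 (0.03 log units; within the scatter) is within the scatter. Compound 3 `CC(C)[C@H](C(=O)NC1=NC(=O)CS1)c1ccc(Cl)cc1` gives 20000 nM, the highest of the three numbers, with a 14-fold higher number from compound 1 to compound 3 (1.15 log units; beyond the scatter) and a 15-fold higher number from compound 2 to compound 3 (1.19 log units; beyond the scatter) both beyond the scatter.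

Compound 4 `CC(C)[C@H](C(=O)Nc1ncc(C#N)s1)c1ccc(Cl)cc1` is compound 3 with a group of 7 heavy atoms (4 carbon, 2 nitrogen, 1 sulfur; one five-membered aromatic ring with 2 hetero atoms) in place of a group of 6 heavy atoms (3 carbon, 1 nitrogen, 1 oxygen, 1 sulfur; one five-membered non-aromatic ring with 2 hetero atoms), on an amide-type nitrogen. Among the compounds with values here, no measured pair covers this exact exchange, but the two steps that lead to compound 3 both show that exchanging a six-membered aromatic ring for the non-aromatic five-membered ring raised the number strongly, as in a 14-fold higher number from compound 1 to compound 3 (1.15 log units; beyond the scatter) and a 15-fold higher number from compound 2 to compound 3 (1.19 log units; beyond the scatter). Compound 4 restores an aromatic ring on the same nitrogen, although a five-membered one with two hetero atoms and a nitrile, so the expected direction is back toward lower numbers in this assay, with a size estimated around an 8.0-fold lower number from compound 3 to compound 4 (0.90 log units; beyond the scatter) rather than a full return to the pyridine compounds. On that basis compound 4 is expected to give about 2500 nM, estimated within a range from 600 nM to 10000 nM.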

Compound 4, half-maximal inhibitory concentration: 2000 nM
Compound 4: the middle estimate sits 1.3-fold (0.10 log units) above what was measured; the measured number falls inside the stated range.
By their numbers in this assay, from the lowest: compounds 2, 1 and 4 (each within the scatter of the next); then compound 3.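

In this assay, the amide-type nitrogen proves not to need a six-membered aromatic ring: 5-cyano-1,3-thiazol-2-yl, a five-membered aromatic ring, in place of the non-aromatic five-membered ring recovers the loss seen with compound 3 (a 10-fold lower number from compound 3 to compound 4 (1.00 log units; beyond the scatter)). The exchanges of pyridin-2-yl (a 1.4-fold higher number from compound 1 to compound 4 (0.15 log units; within the scatter)) and of 5-fluoropyridin-2-yl (a 1.5-fold higher number from compound 2 to compound 4 (0.19 log units; within the scatter)) for this group both stay within the scatter, so compound 4 cannot be told apart from compound 1 or compound 2 at this position. Aromatic rings of both sizes, with different substituents, therefore read alike here, and only the non-aromatic ring of compound 3 stands apart, though no measured property is at hand to explain the difference.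

Going by these compounds, what the nitrile contributes on its own stays open, as does whether a plain 1,3-thiazol-2-yl, or one carrying a carboxylic acid or an amine in its place, would read like compound 4. Also open, on these data alone, is how a longer chain in place of a ring on the same nitrogen would behave.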